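Methoxy Count on the Pendant Phenyl Ring

This account rests on a few compounds, and the source may have more. Where it says the series, first, only, none or still open, it means among the compounds named here.

Compound 1, `COc1cc(/C=C/C(=O)c2cccc(-n3cc(-c4ccc(Cl)cc4)[nH]c3=O)c2)cc(OC)c1OC`, gives 6650 nM in a functional assay on T47D cells (Homo sapiens) for inhibition; on this read-out lower numbers stand for stronger inhibition of growth and higher numbers for weaker inhibition of growth.
Compound 2, `COc1cc(/C=C/C(=O)c2cccc(-n3cc(-c4ccccc4)[nH]c3=O)c2)cc(OC)c1OC`, gives 2190 nM in this assay.
Compound 3, `COc1ccc(-c2cn(-c3cccc(C(=O)/C=C/c4cc(OC)c(OC)c(OC)c4)c3)c(=O)[nH]2)cc1`, gives 3840 nM in this assay.

Compound 3 stands second highest of the three numbers, with compound 1 nearby and compound 2 a little further off; both gaps are within the scatter. Compound 4, `COc1cc(/C=C/C(=O)c2cccc(-n3cc(-c4cc(OC)c(OC)c(OC)c4)[nH]c3=O)c2)cc(OC)c1OC`, carries 3,4,5-trimethoxyphenyl in place of 4-methoxyphenyl on an aromatic carbon. Among the compounds with values here, no measured step adds two methoxy groups at once. The closest guide is a 1.8-fold higher number from compound 2 to compound 3 (0.24 log units; within the scatter), and a 1.7-fold lower number from compound 1 to compound 3 (0.24 log units; within the scatter) also stayed small, so a single methoxy change here moved the number little. Adding two more is therefore expected to bring only a small shift, if any beyond the scatter, perhaps toward a higher number. Compound 4 is expected at 5000 nM, in a range from 1500 nM to 16000 nM, which means an estimated 1.3-fold higher number from compound 3 to compound 4 (0.11 log units; within the scatter).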

Compound 4, concentration for 50% growth inhibition: 3080 nM
Beside the measured number, compound 4's estimate is 1.6-fold (0.21 log units) above it; the measured number falls inside the stated range.
By their numbers in this assay, from the lowest: compounds 2, 4, 3 and 1 (each within the scatter of the next, the first and the last beyond it).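

In this assay, the 3,4,5-trimethoxyphenyl group gives a 1.2-fold lower number from compound 3 to compound 4 (0.10 log units; within the scatter) against 4-methoxyphenyl and a 1.4-fold higher number from compound 2 to compound 4 (0.15 log units; within the scatter) against plain phenyl, so this position accepts the larger group with no clear gain or loss. Against 4-chlorophenyl, the same group gives a 2.2-fold lower number from compound 1 to compound 4 (0.33 log units; beyond the scatter), a modest step. Nothing available here bears on why these numbers stay so close. The compounds shown leave open whether an amine or a carboxylic acid on this phenyl ring would move the number further. They also leave open what a longer chain at this place would do.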